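A few compounds are considered here, and "the series" means these few. Any claim that something is new, unique, unknown or untested is made for them only; others in the source may bear on it.

In a functional assay on VSMC cells (Rattus norvegicus) (a lower number here means a stronger inhibitor, a higher number a weaker inhibitor), compound 1 `Cc1c(O)c(C)c2c(c1O)C(=O)CC(c1ccc(Cl)cc1)O2` has no single number and is recorded as "not active" (no number reported). Compound 2 `Cc1c(O)c(C)c2c(c1O)C(=O)CC(c1ccc([N+](=O)[O-])cc1)O2` is recorded in the same way, as "not active" (no number reported). Compound 3 `COc1cc(O)ccc1C1CC(=O)c2c(O)c(C)c(O)c(C)c2O1` gives > 100000 nM, which is a limit of the assay and not a number. Compound 4 `Cc1c(O)c(C)c2c(c1O)C(=O)CC(c1ccsc1)O2` has not yet been measured. The change places thiophen-3-yl in place of 4-chlorophenyl on a saturated ring carbon. Among the measured compounds shown here, no measured step is available to size this change, so no shift beyond the usual scatter is expected in this assay. That expectation rests on (the limit of > 100000 nM in this assay, at which 1 of the 3 values shown sits), together with the two entries that lack a number. For compound 4 the expected value is 100000 nM, with an estimated range from 20000 nM to 300000 nM.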

Compound 4, half-maximal inhibitory concentration: "not active" (no number reported)
Nothing numeric was reported for compound 4, and the estimate cannot be compared.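

Compound 1 and compound 4 are both recorded as not active without a number in this assay, so no step can be read between them. The compounds shown leave open whether any change on the shared core can produce measurable inhibition.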